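The compounds below may be only part of what the source reports. "The series", "measured", "known", "first", "only" and "open" are said of these compounds alone.

Measured compounds

- compound 1, `COc1cccc(-c2c(-c3ccccc3)c(-c3ccccc3)n3ccc(C#N)cc23)c1`: in an assay for inhibition of Polyunsaturated fatty acid lipoxygenase ALOX15 (Oryctolagus cuniculus) (on this read-out higher numbers stand for weaker inhibition and lower numbers for stronger inhibition), compound 1 gives "not determined" (no result reported)
- compound 2, `N#Cc1ccn2c(-c3ccccc3)c(-c3ccccc3)c(OCOCc3ccccc3)c2c1`: in this assay compound 2 gives 39000 nM
- compound 3, `COc1ccccc1-c1c(-c2ccccc2)c(-c2ccccc2)n2ccc(C#N)cc12`: in this assay compound 3 gives "not determined" (no result reported)

Compound 2 stands alone on the numbers. It is the only one of the three with a value in this assay, and that value sits at the weak end of inhibition. Going by the values given here, compounds 1 and 3 carry no number, so they give no point of comparison, and no step between measured compounds exists. Nothing measured shows how a change on the oxygen on the aromatic ring moves the read-out.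

Compound 4, `Cc1ccc(S(=O)(=O)Oc2c(-c3ccccc3)c(-c3ccccc3)n3ccc(C#N)cc23)cc1`, follows from compound 2 by one change: (4-methylphenyl)sulfonyl in place of (benzyloxy)methyl on an oxygen on an aromatic ring. The (benzyloxy)methyl group is exchanged for a (4-methylphenyl)sulfonyl group on the same oxygen, the ring itself and the two phenyl groups on the core being kept.

Among the compounds with values here, with no measured step to anchor a direction, the only guide is the value of compound 2. On that basis the step from compound 2 to compound 4 is expected to be a 1.0-fold higher number from compound 2 to compound 4 (0.01 log units; within the scatter), estimated to stay within the scatter rather than beyond it, in either direction. Compound 4 is expected to give 40000 nM, within a range from 10000 nM to 160000 nM.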

Compound 4, half-maximal inhibitory concentration: 25000 nM
Beside the measured number, compound 4's estimate is 1.6-fold (0.20 log units) above it; the range from low to high includes it.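

In this assay, going by these compounds alone, exchanging (benzyloxy)methyl for (4-methylphenyl)sulfonyl on the oxygen on an aromatic ring gives a 1.6-fold lower number from compound 2 to compound 4 (0.19 log units; within the scatter), the only step that can be read so far. Both groups carry one six-membered aromatic ring of carbon only, and this pair gives no sign that the read-out depends on which of the two sits on that oxygen, although the link from the oxygen to the ring differs. Nothing available accounts for this outcome or connects it to a feature of either group.

Steps involving compound 1 and compound 3 cannot be read, so the effect of a methoxyphenyl group attached directly to the shared core, in place of these oxygen-linked groups, remains open. From the compounds shown here alone, it is also open whether the read-out would shift with a group lacking the aromatic ring at this oxygen, such as a small methyl ether, a free hydroxyl or a short chain ending in an amine or a carboxylic acid.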